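Series notes: ring methyl, step from compound 2 to compound 3

A few compounds are considered here, and "the series" means these few. Any claim that something is new, unique, unknown or untested is made for them only; others in the source may bear on it.

Measured so far:
compound 1 `O=C(O)CCCCCCc1sccc1CCCc1ccccc1`: 1000 nM
compound 2 `CC(CCCCCc1sccc1CCCc1ccccc1)C(=O)O`: 110 nM

Among the compounds with values here, in an assay on spleen (Cavia porcellus) with leukotriene B4 receptor 1 (Homo sapiens) as the target (on this read-out higher numbers stand for weaker inhibition and lower numbers for stronger inhibition), compound 2 stands lowest of the two numbers; the only measured step in the set is a 9.1-fold lower number from compound 1 to compound 2 (0.96 log units; beyond the scatter), and it concerns a saturated chain carbon.

Compound 3 `Cc1cc(CCCc2ccccc2)c(CCCCCC(C)C(=O)O)s1` differs from compound 2 by methyl in place of hydrogen on an aromatic carbon. No measured step touches an aromatic carbon of the core, so nothing shown bears directly on this change. The expectation is therefore a step of no size beyond the scatter: no change at the digits printed from compound 2 to compound 3 (within the scatter) is the estimated step. Compound 3 is expected at 110 nM, with a range from 35 nM to 350 nM.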

Compound 3, half-maximal inhibitory concentration: 300 nM
The estimate for compound 3 lay 2.7-fold (0.44 log units) below the measured number; the measured number falls inside the stated range.
By their numbers in this assay, from the lowest: compound 2; then compound 3; then compound 1.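

In this assay, methyl in place of hydrogen on an aromatic carbon next to the ring sulfur gives a 2.7-fold higher number from compound 2 to compound 3 (0.44 log units; beyond the scatter), so this ring position does respond to substitution, a point the chain change alone could not show. The step runs in the opposite direction to a 9.1-fold lower number from compound 1 to compound 2 (0.96 log units; beyond the scatter) and lies at a different place on the molecule. No available evidence explains the higher number at this position.

Going by these compounds, whether the step is specific to methyl stays open, since chlorine, methoxy or an ethyl group at this ring carbon would be needed to tell. Also open, on these data alone, is whether the same ring methyl gives a similar step on the chain without its methyl.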